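This account rests on a few compounds, and the source may have more. Where it says the series, first, only, none or still open, it means among the compounds named here.

Of the compounds shown here, three carrying a shared core have been measured in a functional assay on A549 cells (Homo sapiens) for cytotoxicity, read by MTT assay, with a stated time of 48 h; on this read-out higher numbers stand for weaker inhibition and lower numbers for stronger inhibition. Compound 1 `COc1cc(-c2nnc3n2NC(c2cccs2)C(C(=O)c2ccc(F)cc2)S3)cc(OC)c1OC` gives 45000 nM in this assay. Compound 2 `COc1cc(-c2nnc3n2NC(c2ccco2)C(C(=O)c2ccco2)S3)cc(OC)c1OC` gives 68700 nM in this assay. Compound 3 `COc1cc(-c2nnc3n2NC(c2ccco2)C(C(=O)c2ccc(C(F)(F)F)cc2)S3)cc(OC)c1OC` gives 37200 nM in this assay. On these numbers compound 2 sits at the upper end of the three, but its gap to compound 1 and its gap to compound 3 both lie within the scatter, so no ordering among them can be read.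

Compound 4 `COc1cc(-c2nnc3n2NC(c2ccco2)C(C(=O)c2ccccc2C)S3)cc(OC)c1OC` is not yet measured. It differs from compound 2 in one place: 2-methylphenyl in place of furan-2-yl on a carbonyl carbon.

For the measured compounds named here, only one measured step touches the same place, the change from furan-2-yl to 4-(trifluoromethyl)phenyl on the carbonyl carbon, which gave a 1.8-fold lower number from compound 2 to compound 3 (0.27 log units; within the scatter). That step did not leave the scatter. Nothing else in the series speaks to the group on the carbonyl carbon, so no step beyond the scatter is expected in this assay for the present change either.

Compound 4 is therefore expected to give about 50000 nM in this assay, in a range from 25000 nM to 100000 nM. The expected step is a 1.4-fold lower number from compound 2 to compound 4 (0.14 log units; within the scatter), a change that is expected to stay within the scatter.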

Compound 4, half-maximal inhibitory concentration: 80000 nM
Estimate against measurement, compound 4: 1.6-fold (0.20 log units) below; low and high end bracket the measured number.
By their numbers in this assay, from the lowest: compounds 3, 1, 2 and 4 (each within the scatter of the next, the first and the last beyond it).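

In this assay, the group on the carbonyl carbon now gives its first step beyond the scatter, with a 2.2-fold higher number from compound 3 to compound 4 (0.33 log units; beyond the scatter) being modest in size and separating 2-methylphenyl from 4-(trifluoromethyl)phenyl. Furan-2-yl stays unseparated from either group, since a 1.2-fold higher number from compound 2 to compound 4 (0.07 log units; within the scatter) also lies within the scatter, so compound 2 cannot be ranked against compound 3 or compound 4 even though those two differ from each other. Nothing at hand bears on what lies behind the separation of compound 3 from compound 4.

Open is whether the separation belongs to the 2-methylphenyl group, the 4-(trifluoromethyl)phenyl group or both, as an unsubstituted phenyl is not among the compounds shown. Also open, from the compounds shown here alone, is how an amine or a carboxylic acid on that carbonyl carbon would compare with compound 2.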